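The source may report more compounds than this note shows. Statements on the series, on what has been measured and on what is new or still open speak of the compounds shown alone.

Working notes on the series.

Compound 1 `C=Cc1nc2ccccc2[se]1` and compound 2 `C#Cc1nc2ccccc2[se]1` share one core; compound 3 `C=Cc1nc(C(=O)OCC)cs1` and compound 4 `C#Cc1nc(C(=O)OCC)cs1` share another. The difference between the two cores is not broken down here.

In a functional assay on HCT-116 cells (Homo sapiens) for cytotoxicity, with a stated time of 3 days (a higher number here means a weaker inhibitor, a lower number a stronger inhibitor), compound 1 gives only a limit, > 40000 nM. In this assay compound 2 gives 25000 nM. The change between them, (ethynyl in place of vinyl on an aromatic carbon), thus made a step of an at least 1.6-fold lower number from compound 1 to compound 2 (0.20 log units; that floor lies within the scatter); since the starting point is a limit, only a floor for that step is known, and the floor lies within the scatter, as the limit of > 40000 nM in this assay, at which 2 of the 3 values shown sit, reminds.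

In this assay compound 3 gives only a limit, > 40000 nM. Compound 4 carries the same kind of change, (ethynyl in place of vinyl on an aromatic carbon), but the surroundings differ: in compound 2 the ethynyl sits next to the ring nitrogen and next to the ring selenium, in a ring that is part of a fused or bridged system of two rings, whereas in compound 4 it sits next to the ring nitrogen and next to the ring sulfur, two ring bonds from the ring atom that bears a group of 5 heavy atoms.

For compound 4 a step of a number no higher from compound 3 to compound 4 (the limit leaves the size open) is expected, resting on the step from compound 1 to compound 2 of an at least 1.6-fold lower number from compound 1 to compound 2 (0.20 log units; that floor lies within the scatter), whose floor is small. Compound 4 is estimated at 40000 nM, with a range from 20000 nM to 100000 nM, and a fair chance that this assay again reports only a limit.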

Compound 4, half-maximal inhibitory concentration: > 40000 nM
Compound 4 was reported as a limit (the forecaster's own chance of this, stated with the estimate: 55%); the middle value sits exactly at the limit.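

In this assay, among the compounds shown here, compound 3 and compound 4 are both reported only as limits, so no step between them can be read, and the result adds one more entry at the ceiling of the assay: the limit of > 40000 nM in this assay, at which 3 of the 4 values shown sit. The compounds shown leave open how large the change from vinyl to ethynyl is on the core of compound 3, and whether the step seen on the core of compound 1 carries over to it.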